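Chain substituent swap on the shared core: methoxy to vinyl

The compounds below may be only part of what the source reports. "The series", "measured", "known", "first", "only" and "open" are said of these compounds alone.

Compound 3 `COCCn1c(Cc2cc(OC)c(OC)c(OC)c2)nc2c(N)nc(F)nc21` gives 64600 nM in a functional assay on MCF7 cells (Homo sapiens) for antiproliferative activity (a lower number here means a stronger inhibitor, a higher number a weaker inhibitor), the highest number among the three measured here. Compound 1 `CC#CCCn1c(Cc2cc(OC)c(OC)c(OC)c2)nc2c(N)nc(F)nc21` gives 37200 nM and the step of a 1.7-fold higher number from compound 1 to compound 3 (0.24 log units; within the scatter) stays within the scatter; compound 2 `COc1cc(Cc2nc3c(N)nc(F)nc3n2CC2CCCO2)cc(OC)c1OC` gives 22900 nM and the step of a 2.8-fold higher number from compound 2 to compound 3 (0.45 log units; beyond the scatter) goes beyond it. Compound 4 `C=CCCn1c(Cc2cc(OC)c(OC)c(OC)c2)nc2c(N)nc(F)nc21` differs from compound 3 by vinyl in place of methoxy on a saturated chain carbon, two bonds along the chain from an aromatic nitrogen. The measured step at this same place is a 1.7-fold higher number from compound 1 to compound 3 (0.24 log units; within the scatter), where prop-1-yn-1-yl gave way to methoxy without leaving the scatter. Replacing methoxy with vinyl is therefore expected to give a small step if any, more likely toward a lower number. For compound 4 the expected step is a 1.6-fold lower number from compound 3 to compound 4 (0.21 log units; within the scatter). Compound 4 is estimated at 40000 nM, between 15000 nM and 100000 nM.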

Compound 4, half-maximal inhibitory concentration: 33100 nM
Estimate against measurement, compound 4: 1.2-fold (0.08 log units) above, within the range that was stated.
By their numbers in this assay, from the lowest: compounds 2, 4, 1 and 3 (each within the scatter of the next, the first and the last beyond it).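

In this assay, vinyl in place of methoxy gives a 2.0-fold lower number from compound 3 to compound 4 (0.29 log units; within the scatter) and vinyl in place of prop-1-yn-1-yl gives a 1.1-fold lower number from compound 1 to compound 4 (0.05 log units; within the scatter) at this place on the chain. Allyl in place of oxolan-2-yl gives a 1.4-fold higher number from compound 2 to compound 4 (0.16 log units; within the scatter) and so compound 4 stays within the scatter of all three others, even though compound 2 and compound 3 are separated by a 2.8-fold higher number from compound 2 to compound 3 (0.45 log units; beyond the scatter) as their own step. Going by these compounds, whether an amine, a carboxylic acid or a longer chain here would move the number beyond the scatter from compound 4 remains open. No measurement shown here accounts for these steps.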